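Compound 2 and the step to compound 4

The source may report more compounds than this note shows. Statements on the series, on what has been measured and on what is new or still open speak of the compounds shown alone.

- compound 1 `COc1ccc(/C=C2\CN(C)C/C(=C\c3ccccc3F)C2=O)cc1OC` gives 8760 nM
- compound 2 `CN1C/C(=C\c2cccc([N+](=O)[O-])c2)C(=O)/C(=C/c2ccccc2F)C1` gives 1080 nM
- compound 3 `COc1cc(/C=C2\CN(C)C/C(=C\c3ccc(Cl)cc3)C2=O)cc(OC)c1` gives 5950 nM

In a functional assay on HepG2 cells (Homo sapiens) for cytotoxicity, read by MTT assay, with a stated time of 24 h (on this read-out higher numbers stand for weaker inhibition and lower numbers for stronger inhibition), compound 2 gives the lowest number of the three, and compound 3 and compound 1 both lie above it, beyond the scatter. Among the compounds with values here, compound 2 at 1080 nM is the only measured compound with a nitrophenyl group. Compound 1 shares its 2-fluorophenyl yet gives 8760 nM so that group alone does not go with a low number here.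

Within the data shown here, compound 4 `CN1C/C(=C\c2cccc(Br)c2)C(=O)/C(=C/c2cccc([N+](=O)[O-])c2)C1` keeps the nitrophenyl group and has 3-bromophenyl in place of 2-fluorophenyl on a double-bonded chain carbon bound to a double-bonded ring carbon as its single change. Among the measured compounds shown here, no measured pair differs in one place, so this change has no direct precedent. The expected move in this assay is a 1.7-fold higher number from compound 2 to compound 4 (0.22 log units; within the scatter) and is estimated as a modest rise in the number, not clearly beyond the scatter. Compound 4 is expected at 1800 nM with an estimated range from 600 nM to 5500 nM in this read-out.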

Compound 4, half-maximal inhibitory concentration: 4890 nM
Compound 4: middle estimate off by 2.7-fold (0.43 log units), on the low side; the range from low to high includes it.
By their numbers in this assay, from the lowest: compound 2; then compounds 4, 3 and 1 (each within the scatter of the next).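

Working from this assay, the swap of 2-fluorophenyl for 3-bromophenyl on a double-bonded chain carbon bound to a double-bonded ring carbon gives a 4.5-fold higher number from compound 2 to compound 4 (0.66 log units; beyond the scatter) and is the only single-place step in the series so far. This position therefore responds to the group it carries, and the nitrophenyl group, present in both compounds, does not by itself keep the number near that of compound 2 at 1080 nM in this read-out. No measurement on hand explains the size or direction of this step.

Going by these compounds, the step changes both the halogen and the name-position of the ring substituent, so it remains open whether the rise follows the bromine or its placement. Also open, on these data alone, is how a phenyl ring bearing an amine or a carboxylic acid would read at this same position.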